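Methyl for Methylamino on a Thiophene Nucleoside Core

This account rests on a few compounds, and the source may have more. Where it says the series, first, only, none or still open, it means among the compounds named here.

Compound 2 `C#Cc1cn([C@@H]2O[C@H](CO)[C@@H](O)[C@H]2O)c2ncnc(NC)c12` and compound 1 `C#Cc1cn([C@@H]2O[C@H](CO)[C@@H](O)[C@H]2O)c2ncnc(C)c12` share a core and differ in a single group: methyl in place of methylamino on an aromatic carbon. In an ADME assay on BJ cells (Homo sapiens), read by MTT assay, with a stated time of 72 h (a lower number here means a stronger inhibitor, a higher number a weaker inhibitor), compound 2 gives 86000 nM, while compound 1 gives 50 nM, which is a 1700-fold lower number from compound 2 to compound 1 (3.24 log units; beyond the scatter). Compound 3 `CNc1ncnc2c1c(-c1ccsc1)cn2[C@@H]1O[C@H](CO)[C@@H](O)[C@H]1O` keeps the methylamino of compound 2 but sits on a different core, and the two cores differ as follows: thiophen-3-yl in place of ethynyl on an aromatic carbon. For compound 3 this assay reports only a limit, > 100000 nM, so its value is not known as a number. The step of an at least 1.1-fold higher number from compound 2 to compound 3 (0.06 log units; that floor lies within the scatter) therefore gives only a floor and says little on its own. Compound 4 `Cc1ncnc2c1c(-c1ccsc1)cn2[C@@H]1O[C@H](CO)[C@@H](O)[C@H]1O` has not yet been measured; it stands to compound 3 exactly as compound 1 stands to compound 2, and the change is the same: methyl in place of methylamino on an aromatic carbon. Compound 4 is expected to show a step of an at least 500-fold lower number from compound 3 to compound 4 (2.69 log units; beyond the scatter) in this assay, an expectation resting on a 1700-fold lower number from compound 2 to compound 1 (3.24 log units; beyond the scatter). Compound 4 is estimated at 200 nM, with a likely range from 30 nM to 3000 nM.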

Compound 4, half-maximal inhibitory concentration: 96900 nM
Beside the measured number, compound 4's estimate is 480-fold (2.69 log units) below it; measured number above the stated range.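

In this assay compound 3 gives > 100000 nM, which is a limit of the assay and not a number. The result, an at least 1.0-fold lower number from compound 3 to compound 4 (0.01 log units; that floor lies within the scatter), therefore neither shows that the large fall seen with methyl in place of methylamino on the core of compound 1 carries over to the core of compound 3, nor shows that the change behaves differently there, and the steps that rest on this limit cannot be read as sizes: the same change on two cores in this assay, a 1700-fold lower number (3.24 log units; beyond the scatter) from compound 2 to compound 1 and an at least 1.0-fold lower number (0.01 log units; that floor lies within the scatter) from compound 3 to compound 4; the limit leaves it open whether they differ

The one step that can be read is a 1900-fold higher number from compound 1 to compound 4 (3.29 log units; beyond the scatter), which shows that, with methyl present, having thiophen-3-yl in place of ethynyl matters a great deal, while the matching step with methylamino present gives only a floor: the same change on two cores in this assay, an at least 1.1-fold higher number (0.06 log units; that floor lies within the scatter) from compound 2 to compound 3 and a 1900-fold higher number (3.29 log units; beyond the scatter) from compound 1 to compound 4; the limit leaves it open whether they differ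

Going by these compounds, how far compound 3 lies past its limit stays open, and so does the true size of the methyl step on this core. Also open, on these data alone, is whether a plain amine or a chlorine atom in place of methyl would behave the same way on both cores.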